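The source may hold more compounds than are shown below. What is called first, only, known or untested is meant among the compounds shown, and "the series" means these compounds.

Compound 1 `CC(=O)Nc1ccc(CNCC2(O)CCN(CCCc3c[nH]c4ccc(-n5cnnc5)cc34)CC2)cc1`: 30 nM. Compound 2 `CN(CC(C)(C)C)CC1(O)CCN(CCCc2c[nH]c3ccc(-n4cnnc4)cc23)CC1`: 61 nM. Compound 3 `CN(CC1CCCCC1)CC1(O)CCN(CCCc2c[nH]c3ccc(-n4cnnc4)cc23)CC1`: 27 nM.

In an assay on CHO cells with 5-hydroxytryptamine receptor 1B (Homo sapiens) as the target (a higher number here means a weaker inhibitor, a lower number a stronger inhibitor), compound 1 stands second highest of the three numbers; compound 2 gives the higher number, while compound 3 lies within the scatter of compound 1. Compound 4 `CC(C)(C)OC(=O)NCC1(O)CCN(CCCc2c[nH]c3ccc(-n4cnnc4)cc23)CC1` is not yet measured. It differs from compound 1 by tert-butoxycarbonyl in place of 4-acetamidobenzyl on an amine nitrogen. The steps that touch the same amine nitrogen are a 2.0-fold higher number from compound 1 to compound 2 (0.31 log units; beyond the scatter) and a 1.1-fold lower number from compound 1 to compound 3 (0.05 log units; within the scatter), one modest and one within the scatter, but both keep an amine bearing a saturated chain carbon, whereas tert-butoxycarbonyl brings 0 hydrogen-bond donors and 2 hydrogen-bond acceptors. Going by the values given here, no measured pair covers such a change, so a modest weakening with wide uncertainty is expected; the expected step is a 3.0-fold higher number from compound 1 to compound 4 (0.48 log units; beyond the scatter). Compound 4 is estimated at 90 nM, between 25 nM and 320 nM.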

Compound 4, half-maximal inhibitory concentration: 340 nM
Compound 4: middle estimate off by 3.8-fold (0.58 log units), on the low side; measured number outside the range, above it.
By their numbers in this assay, from the lowest: compounds 3 and 1 (each within the scatter of the next); then compound 2; then compound 4.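

In this assay, going by these compounds alone, the amines on this nitrogen differ by modest steps at most, but tert-butoxycarbonyl in place of 4-acetamidobenzyl gives an 11-fold higher number from compound 1 to compound 4 (1.05 log units; beyond the scatter), the first large step at this position. The change also holds against the other two amines, with a 13-fold higher number from compound 3 to compound 4 (1.10 log units; beyond the scatter) and the smaller, modest a 5.6-fold higher number from compound 2 to compound 4 (0.75 log units; beyond the scatter), leaving compound 4 the weakest of the set. Nothing measured here explains the size of this change. It remains open whether the carbonyl on the nitrogen or the tert-butyl group accounts for the change, since the compounds shown include no methyl carbamate, acetamide or unsubstituted amine at this position.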